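A few compounds are considered here, and "the series" means these few. Any claim that something is new, unique, unknown or untested is made for them only; others in the source may bear on it.

Compound 1 `CC(C)n1cc(S(=O)(=O)c2ccc(CNC(=O)N3Cc4ccncc4C3)cc2)cn1` is the reference point. Going by the values given here, in an ADME assay on microsomes from liver (Homo sapiens) for pharmacokinetics, read by LC-MS, with a stated time of 60 min, tested at 1 uM (on this read-out higher numbers stand for fast clearance and lower numbers for slow clearance), compound 1 gives 4 mL/min/kg, the lowest of the two numbers measured so far. Among the compounds with values here, its only measured neighbour is compound 2 `CCC(=O)N1CCC(S(=O)(=O)c2ccc(CNC(=O)N3Cc4ccncc4C3)cc2)CC1`, which in this assay gives 11 mL/min/kg; the change between them is a 2.8-fold higher number from compound 1 to compound 2 (0.44 log units; beyond the scatter). Compound 3 `O=C(NCc1ccc(S(=O)(=O)C2CCN(C3COC3)CC2)cc1)N1Cc2ccncc2C1` has not yet been measured in this assay. It differs from compound 1 in one place: 1-(oxetan-3-yl)piperidin-4-yl in place of 1-isopropyl-1H-pyrazol-4-yl on a sulfonyl sulfur. The step from compound 1 to compound 2 bears directly on this, since there too a piperidin-4-yl group took the place of the 1-isopropyl-1H-pyrazol-4-yl group on the sulfonyl sulfur, the two piperidines differing only in the group carried with them, 1-propanoyl in compound 2 and 1-(oxetan-3-yl) in compound 3. That single step was modest and beyond the scatter, so a rise of similar size is expected here, although one comparison leaves the uncertainty considerable. For compound 3 the expected step is a 2.3-fold higher number from compound 1 to compound 3 (0.35 log units; beyond the scatter). Compound 3 is therefore estimated at 9 mL/min/kg, with a range from 4 mL/min/kg to 20 mL/min/kg.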

Compound 3, clearance: 10 mL/min/kg
Estimate against measurement, compound 3: 1.1-fold (0.05 log units) below, within the range that was stated.
By their numbers in this assay, from the lowest: compound 1; then compounds 3 and 2 (each within the scatter of the next).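

In this assay a second piperidine on the sulfonyl sulfur also gives a higher number than the 1-isopropyl-1H-pyrazol-4-yl group of compound 1 (a 2.5-fold higher number from compound 1 to compound 3 (0.40 log units; beyond the scatter)), so the rise seen with compound 2 no longer rests on a single example. The new compound also allows a direct comparison of two groups on the same piperidine: oxetan-3-yl in place of propanoyl on the ring nitrogen gives a difference that stays within the usual scatter (a 1.1-fold lower number from compound 2 to compound 3 (0.04 log units; within the scatter)), so this read-out does not separate the two groups and both piperidines belong at about the same level. No measurement here explains why both piperidines differ from the pyrazole or why the two groups on the nitrogen read alike.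

The compounds shown cannot say whether the piperidine ring alone sets this level, since a piperidine with a free amine hydrogen or a simple methyl group on its nitrogen would be needed to test that. They also leave open whether other aromatic rings on the sulfonyl sulfur, such as phenyl or pyridine, would match compound 1 in the same way as the pyrazole.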